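Widening a Lactam Ring on Two Different Cores

This account rests on a few compounds, and the source may have more. Where it says the series, first, only, none or still open, it means among the compounds named here.

Compound 1 `CC1(C)C=C(N2CCCC2=O)c2cc(C#N)ccc2O1` and compound 2 `CC1(C)C=C(N2CCCCC2=O)c2cc(C#N)ccc2O1` share one core, while compound 3 `CC1(C)C=C(N2CCCC2=O)c2ccc(C(F)(F)F)cc2O1` and the not yet measured compound 4 `CC1(C)C=C(N2CCCCC2=O)c2ccc(C(F)(F)F)cc2O1` share another; the difference between the two cores is not broken down here. In a functional assay (trachea) for inhibition, with Cavia porcellus as the target (on this read-out lower numbers stand for stronger inhibition and higher numbers for weaker inhibition), compound 1 gives 1570 nM and compound 2 gives 1100 nM. The change from compound 1 to compound 2 is 2-oxopiperidin-1-yl in place of 2-oxopyrrolidin-1-yl on a double-bonded ring carbon, and it made a 1.4-fold lower number from compound 1 to compound 2 (0.15 log units; within the scatter). In this assay compound 3 gives 5100 nM, the highest of the three numbers. The same change, (2-oxopiperidin-1-yl in place of 2-oxopyrrolidin-1-yl on a double-bonded ring carbon), turns compound 3 into compound 4. A small step is expected from compound 3 to compound 4, namely a 1.3-fold lower number from compound 3 to compound 4 (0.13 log units; within the scatter), because a 1.4-fold lower number from compound 1 to compound 2 (0.15 log units; within the scatter) stayed within the scatter on the other core. Compound 4 is therefore estimated at 3800 nM, with a range from 1800 nM to 8000 nM.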

Compound 4, half-maximal inhibitory concentration: 2970 nM
The estimate for compound 4 lay 1.3-fold (0.11 log units) above the measured number; measured number inside the range.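

In this assay, putting 2-oxopiperidin-1-yl in place of 2-oxopyrrolidin-1-yl gives a 1.7-fold lower number from compound 3 to compound 4 (0.23 log units; within the scatter). Set beside the earlier step, the change behaves alike on both cores: the same change on two cores in this assay, a 1.4-fold lower number (0.15 log units; within the scatter) from compound 1 to compound 2 and a 1.7-fold lower number (0.23 log units; within the scatter) from compound 3 to compound 4, 1.2-fold (0.08 log units) apart, within the scatter of two such steps. This shows that the step carried over from one core to the other as a small one, but each step alone is too small to separate from the usual variation between repeat measurements, so it does not show that the six-membered ring truly improves inhibition on either core, and two cores say nothing certain about a third.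

The compounds shown leave open what a seven-membered lactam, or an open-chain amide, would do on the same double-bonded ring carbon.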